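Adding a fluorine to the chlorophenyl of compound 3

A few compounds are considered here, and "the series" means these few. Any claim that something is new, unique, unknown or untested is made for them only; others in the source may bear on it.

Measured so far:
Compound 1, `CC(C)c1ccc(Nc2ccc3c(OCCCN4CCN(C)CC4)cccc3n2)cc1`, gives 2170 nM.
Compound 2, `CN1CCN(CCCOc2cccc3nc(Nc4ccc(F)c(F)c4)ccc23)CC1`, gives 700 nM.
Compound 3, `CN1CCN(CCCOc2cccc3nc(Nc4cccc(Cl)c4)ccc23)CC1`, gives 1910 nM.

All three share one core and differ only in the ring attached to the nitrogen on an aromatic ring. They were tested in a functional assay on UACC-62 cells (Homo sapiens) for inhibition, read by sulforhodamine B assay, with a stated time of 48 h; a lower number here means a stronger inhibitor of growth, a higher number a weaker inhibitor of growth. On these numbers compound 3 stands second highest of the three; it and compound 1 lie within the scatter of each other, as the step of a 1.1-fold lower number from compound 1 to compound 3 (0.06 log units; within the scatter) shows, while compound 2 sits clearly lower, with a 2.7-fold higher number from compound 2 to compound 3 (0.44 log units; beyond the scatter).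

Compound 4, `CN1CCN(CCCOc2cccc3nc(Nc4ccc(Cl)c(F)c4)ccc23)CC1`, is the next compound. Its change from compound 3 is 4-chloro-3-fluorophenyl in place of 3-chlorophenyl on a nitrogen on an aromatic ring.

The step that bears most on it is the one from a dihalogenated ring to the single chlorine, a 2.7-fold higher number from compound 2 to compound 3 (0.44 log units; beyond the scatter), together with a 3.1-fold lower number from compound 1 to compound 2 (0.49 log units; beyond the scatter), which shows a dihalogenated ring giving a modest drop in this assay. Compound 4 again carries two halogens, though with chlorine rather than fluorine in the 4-position. A modest step down is therefore expected, a 1.9-fold lower number from compound 3 to compound 4 (0.28 log units; within the scatter), and compound 4 is estimated at 1000 nM, with a range from 400 nM to 2500 nM.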

Compound 4, concentration for 50% growth inhibition: 2050 nM
Beside the measured number, compound 4's estimate is 2.1-fold (0.31 log units) below it; measured number inside the range.
By their numbers in this assay, from the lowest: compound 2; then compounds 3, 4 and 1 (each within the scatter of the next).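

In this assay a second halogen on the ring does not by itself bring a lower number: 4-chloro-3-fluorophenyl in place of 3-chlorophenyl gives a 1.1-fold higher number from compound 3 to compound 4 (0.03 log units; within the scatter), and 4-chloro-3-fluorophenyl in place of 4-isopropylphenyl gives a 1.1-fold lower number from compound 1 to compound 4 (0.02 log units; within the scatter). Which halogen is present does count, as the single swap of chloro in place of fluoro on an aromatic carbon gives a 2.9-fold higher number from compound 2 to compound 4 (0.47 log units; beyond the scatter), so in this one pair the lower number stays with the 3,4-difluorophenyl ring. Nothing available here explains that difference.

One pair cannot tell whether this holds for fluoro more widely, and 4-fluorophenyl, with its single fluorine, would bear on that question. From the compounds shown here alone, a ring carrying a nitrile or a methoxy group also remains open, as does any effect of a shorter chain on the shared core.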